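Sulfamoyl in place of methoxycarbonyl on compound 3

This account rests on a few compounds, and the source may have more. Where it says the series, first, only, none or still open, it means among the compounds named here.

In an ADME assay on MT4 cells (Homo sapiens) for cytotoxicity, read by MTT assay, with a stated time of 5 days (a lower number here means that less compound is tolerated, a higher number that more compound is tolerated), compound 1 (`Cc1cc(C)cc(S(=O)(=O)n2c(SCC(=O)Nc3ccc(C(=O)O)cc3)nc3ccccc32)c1`) gives 115000 nM. Compound 2 (`Cc1cc(C)cc(S(=O)(=O)n2c(SCC(=O)Nc3ccccc3Br)nc3ccccc32)c1`) reaches only a limit of the assay, >= 235000 nM. Compound 3 (`COC(=O)c1ccc(NC(=O)CSc2nc3ccccc3n2S(=O)(=O)c2cc(C)cc(C)c2)c(Cl)c1`) gives 145000 nM, which stands within the scatter of compound 1.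

Compound 4 (`Cc1cc(C)cc(S(=O)(=O)n2c(SCC(=O)Nc3ccc(S(N)(=O)=O)cc3Cl)nc3ccccc32)c1`) differs from compound 3 as follows: sulfamoyl in place of methoxycarbonyl on an aromatic carbon. This places sulfamoyl in place of methoxycarbonyl on an aromatic carbon, para to a large group. Going by the values given here, no measured step makes this exact change. The closest is a 1.3-fold higher number from compound 1 to compound 3 (0.10 log units; within the scatter), which also alters the group on the amide-type nitrogen and stays within the scatter. The step of an at least 2.0-fold higher number from compound 1 to compound 2 (0.31 log units; beyond the scatter) goes beyond the scatter, but it exchanges 4-carboxyphenyl for 2-bromophenyl, a larger change of group.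

Going by the step from compound 1 to compound 3, the expected step is a 1.1-fold lower number from compound 3 to compound 4 (0.05 log units; within the scatter), with no change beyond the scatter expected. For compound 4 the estimated value in this assay is 130000 nM, with an expected range of 60000 nM to 250000 nM.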

Compound 4, half-maximal cytotoxic concentration: 25600 nM
The estimate for compound 4 lay 5.1-fold (0.71 log units) above the measured number, and the stated range ends above it.
By their numbers in this assay, from the lowest: compound 4; then compounds 1 and 3 (each within the scatter of the next). At a limit, above all of these: compound 2.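

In this assay, exchanging methoxycarbonyl for sulfamoyl on this aromatic carbon gave a 5.7-fold lower number from compound 3 to compound 4 (0.75 log units; beyond the scatter), although both groups hold 4 heavy atoms, so the number here depends on which group this carbon carries. Compound 4 also sits clearly lower than the other two compounds, with a 4.5-fold lower number from compound 1 to compound 4 (0.65 log units; beyond the scatter) and an at least 9.1-fold lower number from compound 2 to compound 4 (0.96 log units; beyond the scatter), which makes it the lowest of the compounds shown. The comparison with compound 2 rests on a limit, not a number: the limit of >= 235000 nM in this assay, at which 1 of the 4 values shown sits.

As far as these compounds go, what an amine, a carboxamide or a methylsulfonyl group would give on this carbon stays open, so the lower number cannot yet be tied to the sulfamoyl group as a whole or to its nitrogen. Also open, from the compounds shown here alone, is whether the same exchange would lower the number without the chloro group.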